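From Iodo to Ethoxy on a Shared Core

This account rests on a few compounds, and the source may have more. Where it says the series, first, only, none or still open, it means among the compounds named here.

Three compounds sharing one core differ only in the halogen on a saturated ring carbon. In a functional assay on MKN-28 cells (Homo sapiens) for cytotoxicity, read by MTT assay (on this read-out higher numbers stand for weaker inhibition and lower numbers for stronger inhibition), compound 1 `C=C1C(=O)[C@]23C[C@@]1(Cl)CC[C@H]2[C@@]12C=CC(=O)[C@](C)(C(=O)O1)[C@H]2[C@@H]3C(=O)OC` gives 4800 nM, compound 2 `C=C1C(=O)[C@]23C[C@@]1(F)CC[C@H]2[C@@]12C=CC(=O)[C@](C)(C(=O)O1)[C@H]2[C@@H]3C(=O)OC` gives 4100 nM and compound 3 `C=C1C(=O)[C@]23C[C@@]1(I)CC[C@H]2[C@@]12C=CC(=O)[C@](C)(C(=O)O1)[C@H]2[C@@H]3C(=O)OC` gives 6700 nM. Compound 3 therefore stands within the scatter of both other compounds, and the three numbers do not separate.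

The next structure, compound 4 `C=C1C(=O)[C@]23C[C@@]1(OCC)CC[C@H]2[C@@]12C=CC(=O)[C@](C)(C(=O)O1)[C@H]2[C@@H]3C(=O)OC`, has ethoxy in place of iodo on a saturated ring carbon. Among the measured compounds shown here, the steps that bear on this change are the exchanges among chloro, fluoro and iodo at that carbon. They are a 1.2-fold lower number from compound 1 to compound 2 (0.07 log units; within the scatter), a 1.4-fold higher number from compound 1 to compound 3 (0.14 log units; within the scatter) and a 1.6-fold higher number from compound 2 to compound 3 (0.21 log units; within the scatter), and all three lie within the scatter. For the measured compounds named here, none of the measured compounds carries ethoxy, so these steps offer only limited guidance, and the range must stay wide. With no measured step beyond the scatter, no clear shift in this assay is expected, in either direction. The expected change is a 1.3-fold lower number from compound 3 to compound 4 (0.13 log units; within the scatter). Compound 4 is estimated at 5000 nM, with an expected range from 2200 nM to 11000 nM.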

Compound 4, half-maximal inhibitory concentration: 82700 nM
Compound 4: the middle estimate sits 17-fold (1.22 log units) below what was measured, and the stated range ends below it.
By their numbers in this assay, from the lowest: compounds 2, 1 and 3 (each within the scatter of the next); then compound 4.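

In this assay, this saturated ring carbon turns out to be far less indifferent to its substituent than the halogen exchanges suggested: ethoxy in place of iodo gives a 12-fold higher number from compound 3 to compound 4 (1.09 log units; beyond the scatter), ethoxy in place of fluoro gives a 20-fold higher number from compound 2 to compound 4 (1.30 log units; beyond the scatter), and ethoxy in place of chloro gives a 17-fold higher number from compound 1 to compound 4 (1.24 log units; beyond the scatter), all three steps beyond the scatter and all toward weaker inhibition. Among the compounds shown here, the three halogen compounds remain one group that does not separate, while ethoxy, with three heavy atoms in place of the single iodine and one hydrogen-bond acceptor where iodo has none, stands clearly apart, so the position can respond strongly to a change of group, which no step among the earlier compounds showed. Nothing available explains why ethoxy behaves so differently from the halogens.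

The compounds shown leave open whether the weakening follows the oxygen attached to the ring carbon or the ethyl part beyond it, a question that a hydroxyl, a methoxy or a plain ethyl group at that carbon would begin to separate. They also leave open how a longer chain such as propoxy, or an amine at the same carbon, would read out on the shared core.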